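Cytotoxicity Limits Unchanged by a Heteroaryl Swap

The compounds below may be only part of what the source reports. "The series", "measured", "known", "first", "only" and "open" are said of these compounds alone.

Measured compounds and their values in an ADME assay on HepG2 cells (Homo sapiens) for cytotoxicity, read by CellTiter-Glo and resazurin assay, with a stated time of 72 h; on this read-out higher numbers stand for an effect only at larger amounts of compound and lower numbers for an effect already at smaller amounts:
Compound 1, `COc1cc(OC)cc(-c2ccc(C(=O)N(Cc3cccc(OCCCCCC(=O)O)c3)C(C)C)cc2)c1`, gives > 26000 nM.
Compound 2, `CC(C)N(Cc1cccc(OCCCCCC(=O)O)c1)C(=O)c1ccc(-c2cc3ccccc3n2S(=O)(=O)c2ccccc2)cc1`, gives > 26000 nM.
Compound 3, `CCOC(=O)CCCCCOc1cccc(CN(C(=O)c2ccc(-c3ccc4ccccc4c3)cc2)C(C)C)c1`, gives > 26000 nM.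

Each of these three values is a limit of this assay rather than a number: none of the three compounds caused a measurable loss of cell viability at the highest amount tested. Compound 3 therefore does not stand out in either direction; its value sits at the same limit as the other two, as the data show in the limit of > 26000 nM in this assay, at which 3 of the 3 values shown sit. For the measured compounds named here, with every value at the ceiling, no step between measured compounds can be sized, and no pattern beyond "no effect seen" can be drawn.

Compound 4, `CCOC(=O)CCCCCOc1cccc(CN(C(=O)c2ccc(-c3cccc(-c4nnc(C)o4)c3)cc2)C(C)C)c1`, keeps the core of compound 3 and changes one group: 3-(5-methyl-1,3,4-oxadiazol-2-yl)phenyl in place of naphthalen-2-yl on an aromatic carbon. Going by the values given here, the three compounds measured so far carry different aryl groups at this position and all reach the same limit, so nothing in the data points to this change bringing toxicity into range. The step from compound 3 to compound 4 in this assay is expected to be none beyond the scatter, a step that the limit leaves unreadable from compound 3 to compound 4. Compound 4 is estimated at 40000 nM, with a range from 15000 nM to 150000 nM, and most likely reported only as a limit.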

Compound 4, half-maximal effective concentration: > 26000 nM
Compound 4: only a limit was reported; the forecaster's own chance of this, stated with the estimate: 85%; the middle value does not contradict the limit.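

In this assay, for the compounds shown here, compound 4 gives only a limit rather than a number, as compound 3 does, so no step between compound 3 and compound 4 can be read: the limit of > 26000 nM in this assay, at which 4 of the 4 values shown sit. The compounds shown leave open which change to the shared core, if any, would bring a loss of cell viability into measurable range.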